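The source may report more compounds than this note shows. Statements on the series, on what has been measured and on what is new or still open speak of the compounds shown alone.

Compound 2, `C#CCN(C)/N=N/c1ccc(C(=O)O)cc1`, stands lowest of the three compounds measured in a physicochemical assay for lipophilicity, in phosphate buffer, measured as octanol-water partition, at pH 7.4; on this read-out higher numbers stand for higher lipophilicity and lower numbers for lower lipophilicity: compound 2 gives 0, while compound 3, `CC(C)N(C)/N=N/c1ccc(C(=O)O)cc1`, gives 0.34 and compound 1, `CCC(C)CN(C)/N=N/c1ccc(C(=O)O)cc1`, gives 1.33. The step from compound 2 to compound 3 is a number 0.34 log units higher from compound 2 to compound 3 (beyond the scatter), and the step from compound 1 to compound 2 is a number 1.33 log units lower from compound 1 to compound 2 (beyond the scatter), so replacing the short unsaturated group on the amine nitrogen with a saturated chain has raised the read-out each time, and more so the longer the chain.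

Compound 4, `CCCCCCN(C)/N=N/c1ccc(C(=O)O)cc1`, is not yet measured in this assay. It differs from compound 2 in one place: pentyl in place of ethynyl on a saturated chain carbon bound to an amine nitrogen. The steps from compound 1 to compound 2 and from compound 2 to compound 3 both bear on this change, and since the chain that enters in compound 4 is a carbon longer than the 2-methylbutyl of compound 1, a step at least as large as a number 1.33 log units lower from compound 1 to compound 2 (beyond the scatter) in the opposite direction is expected, with some further rise. The estimated step from compound 2 to compound 4 is therefore a number 1.80 log units higher from compound 2 to compound 4 (beyond the scatter). Compound 4 is expected to give about 1.8 in this assay, within a range from 1.4 to 2.3.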

Compound 4, distribution coefficient: 1.95
For compound 4 the middle estimate is 0.15 log units below the measured one; the measured number falls inside the stated range.
By their numbers in this assay, from the lowest: compound 2; then compound 3; then compound 1; then compound 4.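

At this position, the change to pentyl gives the largest step of the series, a number 1.95 log units higher from compound 2 to compound 4 (beyond the scatter), and the read-out in this assay has not yet levelled off at the top of the measured set. The hexyl group also exceeds both saturated groups already measured, with a number 1.61 log units higher from compound 3 to compound 4 (beyond the scatter) and, for pentyl in place of sec-butyl, a number 0.62 log units higher from compound 1 to compound 4 (beyond the scatter); the four compounds therefore rise in the order compound 2, compound 3, compound 1, compound 4, and none of them goes against that order. Nothing shown explains why the steps have these sizes.

The compounds shown leave open whether a longer chain, such as octyl, would raise the read-out further or whether the rise would stop, and whether a branched chain with the same carbon count as hexyl would match compound 4. They also leave open how a hydroxyl group or an amine at the end of the hexyl chain, or a cyclohexyl ring in its place, would alter the number.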